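Replacing benzyloxy with ethylsulfanyl on an aromatic ring

The compounds below may be only part of what the source reports. "The series", "measured", "known", "first", "only" and "open" are said of these compounds alone.

Compound 1 `O=C(O)c1cnc(-c2ccccc2F)[nH]c1=O`: 5 mg/kg
Compound 2 `CCCOc1ccccc1-c1ncc(C(=O)O)c(=O)[nH]1`: 0.9 mg/kg
Compound 3 `O=C(O)c1cnc(-c2ccccc2OCc2ccccc2)[nH]c1=O`: 5 mg/kg

These compounds share one core and differ in a single group on an aromatic carbon. In a functional assay on the whole organism (strain Sprague-Dawley) for inhibition, with Rattus norvegicus as the target, with a stated time of 10 min (on this read-out higher numbers stand for an effect only at larger amounts of compound and lower numbers for an effect already at smaller amounts), compound 3 gives 5 mg/kg, the same number as compound 1, and these two share the top of this small set. Compound 4 `CCSc1ccccc1-c1ncc(C(=O)O)c(=O)[nH]1` has not yet been measured. It carries ethylsulfanyl in place of benzyloxy on an aromatic carbon, ortho to a large group (ethylsulfanyl in place of benzyloxy on an aromatic carbon).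

For the measured compounds named here, three measured steps bear on this change. Benzyloxy in place of fluoro gave no change at the digits printed from compound 1 to compound 3 (within the scatter). Propoxy in place of fluoro gave a 5.6-fold lower number from compound 1 to compound 2 (0.74 log units; beyond the scatter). Phenyl in place of ethyl on the chain gave a 5.6-fold higher number from compound 2 to compound 3 (0.74 log units; beyond the scatter). Like compound 2, at 0.9 mg/kg, compound 4 has a chain without the ring of benzyloxy. Going by the values given here, no measured compound contains sulfur, so this comparison is only loose. Therefore the estimated change, a somewhat smaller move toward a lower number, is expected to be a 3.3-fold lower number from compound 3 to compound 4 (0.52 log units; beyond the scatter). The estimate for compound 4 is 1.5 mg/kg, with an expected range of 0.6 mg/kg to 4 mg/kg.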

Compound 4, dose for 50% inhibition: 25 mg/kg
Compound 4: middle estimate off by 17-fold (1.22 log units), on the low side, and the stated range ends below it.
By their numbers in this assay, from the lowest: compound 2; then compounds 1 and 3 (each within the scatter of the next); then compound 4.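

In this assay, short chains without a ring are not interchangeable at this position: ethylsulfanyl in place of propoxy gives a 28-fold higher number from compound 2 to compound 4 (1.44 log units; beyond the scatter) and is the largest step in the set. The new group also stands apart from the other two, with ethylsulfanyl in place of benzyloxy giving a 5.0-fold higher number from compound 3 to compound 4 (0.70 log units; beyond the scatter) and ethylsulfanyl in place of fluoro giving a 5.0-fold higher number from compound 1 to compound 4 (0.70 log units; beyond the scatter) as the result, which leaves compound 4 needing the largest dose of the four. Nothing available here accounts for these steps.

Ethylsulfanyl differs from propoxy in both the linking atom and the chain, and the compounds shown do not separate these two changes. A propylsulfanyl or ethoxy group in the same place would show whether the sulfur or the shorter chain goes with the higher number.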